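The compounds below may be only part of what the source reports. "The series", "measured", "known", "first", "only" and "open" are said of these compounds alone.

In a functional assay on HEK-293T cells (Homo sapiens) for cytotoxicity, read by MTT assay (a lower number here means that less compound is tolerated, a higher number that more compound is tolerated), compound 3 `COc1ccc(-c2nc3cnccn3c2Nc2cc(OC)c(OC)c(OC)c2)cc1` gives 54000 nM. That lies within the scatter of compound 2 `COc1ccc(-c2nc3cnccn3c2Nc2cc(OC)c(OC)c(OC)c2)cc1O` at 38000 nM, while compound 1 `COc1ccc(-c2nc3ccccn3c2Nc2cc(OC)c(OC)c(OC)c2)cc1O` shows a clearly lower number, 10000 nM. Compound 4 `COc1cc(Nc2c(-c3cccc(O)c3)nc3cnccn23)cc(OC)c1OC` keeps the core of compound 3 but carries 3-hydroxyphenyl in place of 4-methoxyphenyl on an aromatic carbon. For the measured compounds named here, the one measured step bearing on this is a 1.4-fold higher number from compound 2 to compound 3 (0.15 log units; within the scatter), with hydrogen in place of hydroxy on an aromatic carbon. Going by the values given here, no measured step shows the loss of the methoxy group alone, so that part stays open. No step beyond the scatter is therefore expected in this assay. Compound 4 is estimated at 42000 nM, with an expected range of 18000 nM to 90000 nM.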

Compound 4, concentration lethal to 50% of the cells: 42000 nM
The estimate for compound 4 equals the measured number at the digits printed; measured number inside the range.
By their numbers in this assay, from the lowest: compound 1; then compounds 2, 4 and 3 (each within the scatter of the next).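

In this assay, 3-hydroxyphenyl in place of 4-methoxyphenyl gives a 1.3-fold lower number from compound 3 to compound 4 (0.11 log units; within the scatter), so this aromatic carbon carries either group without a step beyond the scatter. The methoxy group now has a step of its own, a 1.1-fold higher number from compound 2 to compound 4 (0.04 log units; within the scatter), and its loss, like the loss of the hydroxy group, stays within the scatter. Nothing measured here accounts for these small steps. From the compounds shown here alone, whether plain phenyl, or a ring bearing an amine or a carboxylic acid, would also stay within the scatter remains open.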